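The compounds below may be only part of what the source reports. "The series", "measured", "known", "first", "only" and "open" are said of these compounds alone.

Three compounds have been measured in an ADME assay on microsomes from liver (Mus musculus) for metabolic stability, read by LC-MS; a lower number here means slower removal, a higher number faster removal of the compound:
compound 1 `CC1CCC(NC(=O)c2cc3c(Cl)cc(Cl)cc3[nH]2)CC1` gives 37 mL.min-1.g-1;
compound 2 `C[C@H]1CC[C@@H](NC(=O)c2cc3c(Cl)cc(Cl)cc3[nH]2)CC1` gives 47 mL.min-1.g-1;
compound 3 `CC1CCC(NC(=O)c2cc3c(Cl)cccc3[nH]2)CC1` gives 462 mL.min-1.g-1.

All three share the same core. Compound 1 has the lowest of the three numbers. The smallest gap is a 1.3-fold higher number from compound 1 to compound 2 (0.10 log units; within the scatter), and the only thing separating those two structures is the fact that one of compounds 1 and 2 is drawn with a defined configuration and the other without, at the place where they differ. The largest gap is a 12-fold higher number from compound 1 to compound 3 (1.10 log units; beyond the scatter), where a chloro on an aromatic carbon has been replaced by hydrogen.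

Compound 4 `CC1(C)CCC(NC(=O)c2cc3c(Cl)cc(Cl)cc3[nH]2)CC1` has not yet been measured. It differs from compound 1 by methyl in place of hydrogen on a saturated ring carbon. Neither measured step touches this part of the molecule: one changes only how the stereocentres are drawn, the other changes the aromatic part of the core. There is no direct guide for adding a methyl on the saturated ring, so the expectation is a step of no more than modest size in this assay, with wide uncertainty. The estimated step is a 1.5-fold higher number from compound 1 to compound 4 (0.17 log units; within the scatter). Compound 4 is therefore expected to give about 55 mL.min-1.g-1, in a range from 20 mL.min-1.g-1 to 150 mL.min-1.g-1.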

Compound 4, intrinsic clearance in microsomes: 13 mL.min-1.g-1
Beside the measured number, compound 4's estimate is 4.2-fold (0.63 log units) above it; the whole stated range lies above it.
By their numbers in this assay, from the lowest: compound 4; then compounds 1 and 2 (each within the scatter of the next); then compound 3.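

In this assay, the saturated ring proves to matter: methyl in place of hydrogen on a saturated ring carbon, three ring bonds from the ring atom that bears a large group, gives a 2.8-fold lower number from compound 1 to compound 4 (0.45 log units; beyond the scatter), which means slower removal. The earlier compounds shown here showed a change beyond the scatter only in the aromatic part, where hydrogen in place of chloro gave a 12-fold higher number from compound 1 to compound 3 (1.10 log units; beyond the scatter), so the number can now be seen to shift with changes in either part of the molecule. Within the data shown here, nothing measured so far says why adding this methyl lowers the number.

Going by these compounds, whether an ethyl or a hydroxyl on the same ring carbon would lower the number as well remains open. Also open, on these data alone, is whether the same methyl would give a step of similar size on compound 3.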